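The compounds below may be only part of what the source reports. "The series", "measured", "known", "first", "only" and "open" are said of these compounds alone.

Working notes on the series. In a functional assay on HT-1080 cells (Homo sapiens) for cytotoxicity, read by MTT assay, with a stated time of 72 h (on this read-out higher numbers stand for weaker inhibition and lower numbers for stronger inhibition), compound 1 (`COc1ccc(/C=C2\CCC/C(=C\c3cccc(Cl)c3)C2=O)cc1OC`) gives 4900 nM, compound 2 (`COc1ccc(/C=C2\CCC/C(=C\c3ccccc3Br)C2=O)cc1OC`) gives 8400 nM and compound 3 (`COc1cccc(/C=C2\CCC/C(=C\c3ccc(OC)c(OC)c3)C2=O)c1`) gives 4600 nM. Compound 3 therefore stands within the scatter of both other compounds, and no order can be drawn among the three.

Compound 4 (`COc1ccc(/C=C2\CCC/C(=C\c3cccc(O)c3)C2=O)cc1OC`) takes 3-hydroxyphenyl in place of the 3-methoxyphenyl of compound 3, hydrogen in place of methyl on an oxygen on an aromatic ring. Within the data shown here, two measured steps bear on this change: methoxy in place of chloro on an aromatic carbon, a 1.1-fold lower number from compound 1 to compound 3 (0.03 log units; within the scatter), and 3-methoxyphenyl in place of 2-bromophenyl, a 1.8-fold lower number from compound 2 to compound 3 (0.26 log units; within the scatter). Among the measured compounds shown here, both are small, but no hydroxy compound has been measured, so neither shows this change directly. No step beyond the scatter is expected in this assay, and no firm direction can be assigned. The estimate means a 1.1-fold lower number from compound 3 to compound 4 (0.04 log units; within the scatter), an expected step within the scatter. For compound 4 the expected value is 4200 nM, with an estimated range from 1700 nM to 10000 nM.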

Compound 4, half-maximal inhibitory concentration: 1700 nM
Compound 4: the middle estimate sits 2.5-fold (0.39 log units) above what was measured; measured number inside the range.
By their numbers in this assay, from the lowest: compound 4; then compounds 3, 1 and 2 (each within the scatter of the next).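

In this assay, among these compounds, hydrogen in place of methyl on an oxygen on an aromatic ring gives the first steps beyond the scatter (a 2.7-fold lower number from compound 3 to compound 4 (0.43 log units; beyond the scatter)), whereas the earlier changes on this ring all stayed within it. The same holds against the halogen compounds, for hydroxy in place of chloro (a 2.9-fold lower number from compound 1 to compound 4 (0.46 log units; beyond the scatter)) and for 3-hydroxyphenyl in place of 2-bromophenyl (a 4.9-fold lower number from compound 2 to compound 4 (0.69 log units; beyond the scatter)), so compound 4 stands lowest of the four, and this aromatic carbon does respond to the group it carries. Nothing at hand gives a reason for these steps.

As far as these compounds go, whether the lower number is specific to hydroxy or also appears with an amine or a carboxylic acid on the same aromatic carbon stays open. Also open, from the compounds shown here alone, is how a longer ether such as ethoxy compares with the methoxy of compound 3.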